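The source may report more compounds than this note shows. Statements on the series, on what has been measured and on what is new or still open speak of the compounds shown alone.

Of the compounds shown here, three have been tested in an ADME assay on cells (Erythrocyte, Homo sapiens) for activation, read by hemolysis, with a stated time of 30 min, tested at 2.5 mM (a lower number here means a weaker effect, a higher number a stronger effect of the compound at the concentration tested), and only one of them carries a number. Compound 1 `N=C(N)c1ccc(-c2ccc(-c3cc(Cl)cc(Cl)c3)s2)s1` is recorded as "non-toxic" (no number reported), with no figure attached. Compound 3 `N=C(N)c1ccc(-c2ccc(-c3ccc4ccccc4c3)s2)s1` is likewise recorded as "non-toxic" (no number reported). Within the data shown here, compound 2 `N=C(N)c1ccc(-c2ccc(-c3ccc(Cl)cc3)o2)o1` is the one compound with a measured figure: in this assay compound 2 gives 41.3%. On the numbers shown, compound 2 therefore stands alone, and nothing can be said of its order relative to compound 1 or compound 3 beyond the fact that those two were reported without a value.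

Compound 4 `N=C(N)c1ccc(-c2ccc(-c3ccc(F)cc3)o2)o1` differs from compound 2 in a single respect: fluoro in place of chloro on an aromatic carbon. Among the measured compounds shown here, no pair of measured compounds shows this exchange, so its effect in this assay is not known from the data. The exchange of one halogen for another at the same site is expected to move the reading by a moderate amount, if at all, most likely toward a weaker effect, and a shift no larger than the usual scatter is quite possible. For compound 4 the value in this assay is estimated at 30%, within a range from 10% to 50%, which means an expected step of a number 11.3 percentage points lower from compound 2 to compound 4 (beyond the scatter).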

Compound 4, a percentage reported as activity, at one concentration (the size of the read-out at that concentration, not a potency): 17.6%
Compound 4: the middle estimate sits 12.4 percentage points above what was measured; low and high end bracket the measured number.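

Fluoro in place of chloro on an aromatic carbon, para to a large group, gives a number 23.7 percentage points lower from compound 2 to compound 4 (beyond the scatter) in this assay and so shows that the read-out responds to this position. Among these compounds, the earlier compounds offered no pair differing in one place, so this is the first single exchange that can be read, and it shows that the identity of the halogen alone changes the reading while the rest of compound 2 stays the same. Nothing in the data shown explains why the reading moves.

Going by these compounds, what a methyl, a methoxy group or an amine would give on this carbon remains open. On these data alone, it is also open whether the same exchange would matter on the cores of compound 1 and compound 3, whose entries carry no number.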